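A few compounds are considered here, and "the series" means these few. Any claim that something is new, unique, unknown or untested is made for them only; others in the source may bear on it.

In a functional assay on CCRF-CEM cells (Homo sapiens) for antiproliferative activity, read by sulforhodamine B assay, with a stated time of 48 h (on this read-out higher numbers stand for weaker inhibition and lower numbers for stronger inhibition), compound 2 `O=C1NCCN1c1ccc(S(=O)(=O)Nc2cccc(Br)c2)cc1` gives 110 nM. Compound 3 `Cc1ccc(C)c(NS(=O)(=O)c2ccc(N3CCNC3=O)cc2)c1` gives 74 nM, which lies within the scatter of the value for compound 2, so the two count as level. For the measured compounds named here, compound 1 `COc1cc(NS(=O)(=O)c2ccc(N3CCNC3=O)cc2)cc(OC)c1OC` gives 23 nM, a clearly lower number than the one for compound 2. Compound 2 therefore sits with compound 3 at the upper end of these few numbers.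

The compound still to be measured is compound 4 `O=C1NCCN1c1ccc(S(=O)(=O)Nc2cccc(Cl)c2)cc1`. It comes from compound 2 through a single swap, chloro in place of bromo on an aromatic carbon. Going by the values given here, no measured pair shows this exact swap, so the evidence is indirect. Among the compounds with values here, only one measured step alters the same aryl group: a 1.5-fold lower number from compound 2 to compound 3 (0.17 log units; within the scatter), where 2,5-dimethylphenyl replaces 3-bromophenyl on a sulfonamide nitrogen. That is a bigger structural change than the swap from bromo to chloro, yet it stays within the scatter. A step beyond the scatter is therefore not expected in this assay, and the data favour no direction. The expected step is small, a 1.1-fold higher number from compound 2 to compound 4 (0.04 log units; within the scatter), which is an estimate and not a measurement. For compound 4 the estimated value is 120 nM, with an expected range from 55 nM to 260 nM.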

Compound 4, half-maximal inhibitory concentration: 77 nM
For compound 4 the middle estimate is 1.6-fold (0.19 log units) above the measured one; low and high end bracket the measured number.
By their numbers in this assay, from the lowest: compound 1; then compounds 3, 4 and 2 (each within the scatter of the next).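

Chloro in place of bromo on the aromatic carbon, meta to a large group, gives a 1.4-fold lower number from compound 2 to compound 4 (0.15 log units; within the scatter) in this assay and so offers the first direct reading of this swap: at this position the two halogens count as level. Compound 4 also shows a 1.0-fold higher number from compound 3 to compound 4 (0.02 log units; within the scatter) and therefore stands level with the compound carrying 2,5-dimethylphenyl on the sulfonamide nitrogen, so 3-chlorophenyl, 3-bromophenyl and 2,5-dimethylphenyl cannot be told apart by this read-out among these three compounds. No supporting measurement is available to explain why the swap leaves the number within the scatter.

Going by these compounds, the result covers only two halogens at one position on one shared core, so it remains open whether fluoro, an amine or a carboxylic acid at the same position would also stay level with chloro and bromo. On these data alone, it is equally open whether the swap from bromo to chloro would stay this quiet on an aryl group carrying further substituents, such as methoxy groups.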